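A few compounds are considered here, and "the series" means these few. Any claim that something is new, unique, unknown or untested is made for them only; others in the source may bear on it.

Compounds with numbers in hand:

compound 1, `O=S(=O)(NCCCNCc1ccc(Cl)cc1)c1cc(C(F)(F)F)cc(C(F)(F)F)c1`, 4900 nM
compound 2, `CN(CCCNS(=O)(=O)c1cc(C(F)(F)F)cc(C(F)(F)F)c1)Cc1ccccc1`, a limit only, > 50000 nM
compound 3, `O=S(=O)(NCCCNCc1ccccc1)c1cc(C(F)(F)F)cc(C(F)(F)F)c1`, 16000 nM

All three were tested in a functional assay on PANC-1 cells (Homo sapiens) for inhibition, read by MTT assay, with a stated time of 72 h; a higher number here means a weaker inhibitor of growth, a lower number a stronger inhibitor of growth. Among the two numbers that are not limits, compound 1 stands lowest, and compound 3 sits a 3.3-fold higher number from compound 1 to compound 3 (0.51 log units; beyond the scatter). For compound 2 the assay gives only a limit, > 50000 nM, which is the top of its range (the limit of > 50000 nM in this assay, at which 1 of the 3 values shown sits). From there, compound 3 lies an at least 3.1-fold lower number from compound 2 to compound 3 (0.49 log units; beyond the scatter), and compound 2 stands an at least 10-fold higher number from compound 1 to compound 2 (1.00 log units; beyond the scatter).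

The account now turns to compound 4, `O=S(=O)(NCCCNCc1ccc(Br)cc1)c1cc(C(F)(F)F)cc(C(F)(F)F)c1`, which differs from compound 1 in one spot: bromo in place of chloro on an aromatic carbon. Within the data shown here, the one measured step that bears on this position is the removal of the chloro, a 3.3-fold higher number from compound 1 to compound 3 (0.51 log units; beyond the scatter), which shows that a halogen on that aromatic carbon matters in this assay. Among the measured compounds shown here, no step compares two different halogens there. Exchanging bromo for chloro is a smaller change than removing the halogen altogether, so a step no larger than the scatter, in either direction, is expected for compound 4, a 1.3-fold lower number from compound 1 to compound 4 (0.11 log units; within the scatter). Compound 4 is therefore estimated at 3800 nM, between 1600 nM and 9000 nM.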

Compound 4, concentration for 50% growth inhibition: 2200 nM
Estimate against measurement, compound 4: 1.7-fold (0.24 log units) above, and the stated range covers the measured number.
By their numbers in this assay, from the lowest: compound 4; then compound 1; then compound 3. At a limit, above all of these: compound 2.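

Until now, the compounds showed only that a halogen on this aromatic carbon gives a lower number than hydrogen; compound 4 shows that in this assay the choice of halogen also counts, with a 2.2-fold lower number from compound 1 to compound 4 (0.35 log units; beyond the scatter). Together with a 7.3-fold lower number from compound 3 to compound 4 (0.86 log units; beyond the scatter), this puts the three groups in an order, from hydrogen in compound 3 through chloro in compound 1 to bromo in compound 4, and each pairwise step in that order lies beyond the scatter. The widest gap, an at least 22-fold lower number from compound 2 to compound 4 (1.35 log units; beyond the scatter), gives a bound and not an exact size, since compound 2 stands only at a limit: the limit of > 50000 nM in this assay, at which 1 of the 4 values shown sits.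

The compounds shown leave open whether iodo or fluoro on this same carbon would extend the order, and where a methoxy group or a nitrile would fall in it. They also leave open how bromo in place of chloro reads when the amine nitrogen carries a methyl, and the numbers here say nothing about what lies behind the order.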